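A few compounds are considered here, and "the series" means these few. Any claim that something is new, unique, unknown or untested is made for them only; others in the source may bear on it.

Working notes on the series. Compound 1 `CCC1(Cc2ccccc2)OS(=O)(=O)C=C1OCC#N` is one of two measured members; the other is compound 2 `CC(C)CC1(Cc2ccccc2)OS(=O)(=O)C=C1OCc1ccccc1`. In an ADME assay on HEL cells (Homo sapiens) for cytotoxicity, with a stated time of 3 days (a lower number here means that less compound is tolerated, a higher number that more compound is tolerated), compound 1 reaches only the limit of the assay, > 200000 nM, so its position is known as a limit and not as a number. Compound 2 gives 102000 nM in this assay. What is known of where compound 1 stands is summed up by the limit of > 200000 nM in this assay, at which 1 of the 2 values shown sits. Compound 3 `CCC1(Cc2ccccc2)OS(=O)(=O)C=C1OC(=O)c1ccccc1` is not yet measured in this assay. It differs from compound 1 by benzoyl in place of cyanomethyl on an oxygen on an unsaturated carbon. For the measured compounds named here, no step between two measured compounds is available to calibrate this change, so the expectation rests on the limit of compound 1 alone: a step that is small or none beyond the scatter, with a downward direction if any. Compound 3 is therefore expected to give 150000 nM in this assay, within 50000 nM to 300000 nM. The step this implies, an at least 1.3-fold lower number from compound 1 to compound 3 (0.12 log units; that floor lies within the scatter), is an estimate rather than a measurement.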

Compound 3, half-maximal cytotoxic concentration: > 200000 nM
Compound 3 ended at the assay's limit; the forecaster's own chance of this, stated with the estimate: 40%; middle value at least 1.3-fold (0.12 log units) from the limit.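

For the compounds shown here, compound 1 and compound 3 both stand at a limit in this assay, so no step between them can be read: the limit of > 200000 nM in this assay, at which 2 of the 3 values shown sit. Still open, as far as these compounds go, is where compound 1 and compound 3 would fall past that limit, and whether benzoyl in place of cyanomethyl changes the read-out at all.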